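Dihydroindolyl for Methylpiperidinyl on the Thiocarbonyl Carbon

The source may hold more compounds than are shown below. What is called first, only, known or untested is meant among the compounds shown, and "the series" means these compounds.

Compound 1 `CC1CCCCN1C(=S)SCc1ccc(C(=O)Nc2ccccc2N)cc1` was tested in a functional assay on MGC-803 cells (Homo sapiens) for antiproliferative activity, read by CCK-8 assay, with a stated time of 72 h; on this read-out higher numbers stand for weaker inhibition and lower numbers for stronger inhibition; in it compound 1 gives 1610 nM. Compound 2 `Nc1ccccc1NC(=O)c1ccc(CSC(=S)N2CCN(c3ccncc3)CC2)cc1` gives 1580 nM in this assay, so the number of compound 1 is nominally the higher of the two, yet the pair lies within the scatter and cannot be ordered. Compound 3 `Nc1ccccc1NC(=O)c1ccc(CSC(=S)N2CCc3ccccc32)cc1` differs from compound 1 in one place: 2,3-dihydro-1H-indol-1-yl in place of 2-methylpiperidin-1-yl on a thiocarbonyl carbon. Going by the values given here, no step between measured compounds speaks to this change, so no shift beyond the scatter is expected in this assay. Compound 3 is expected to give about 1300 nM, between 450 nM and 3800 nM, an estimated step of a 1.2-fold lower number from compound 1 to compound 3 (0.09 log units; within the scatter) that stays within the scatter.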

Compound 3, half-maximal inhibitory concentration: 2300 nM
Estimate against measurement, compound 3: 1.8-fold (0.25 log units) below; measured number inside the range.
By their numbers in this assay, from the lowest: compounds 2, 1 and 3 (each within the scatter of the next).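

In this assay, putting 2,3-dihydro-1H-indol-1-yl in place of 2-methylpiperidin-1-yl on a thiocarbonyl carbon amounts to a 1.4-fold higher number from compound 1 to compound 3 (0.15 log units; within the scatter). Going by these compounds alone, this is the first one-place change read at this position, and it shows that a group with an added six-membered aromatic ring of carbon only leaves the number indistinguishable from that of the 2-methylpiperidin-1-yl group. No measurement at hand speaks to the reason for this. On these data alone, whether an open-chain diethylamino group or a piperidine ring bearing a carboxylic acid on the thiocarbonyl carbon would shift the number beyond the scatter remains open.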